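The source may hold more compounds than are shown below. What is called first, only, known or untested is meant among the compounds shown, and "the series" means these compounds.

Going by the values given here, in a functional assay with leukotriene B4 receptor (Homo sapiens) as the target (on this read-out higher numbers stand for weaker inhibition and lower numbers for stronger inhibition), compound 2 `O=C(O)c1ccc(C(F)(F)F)cc1-c1ccc2c(c1)OC[C@H](Cc1ccccc1)[C@H]2O` gives 280 nM; this is the only number reported for it, and one further entry carries no single figure. Compound 1 `O=C(O)c1ccc(Cl)cc1-c1ccc2c(c1)OC[C@H](Cc1ccc(-c3ccccc3)cc1)[C@H]2O`, which also carries a chloro group, gives 590 nM; 520 nM (2 entries) in this assay; its repeated entries, (the several entries of compound 1 in this assay, 590 nM; 520 nM (2 entries)), show how closely two runs of the same compound agree here. Compound 3 `O=C(O)c1ccc(Cl)cc1-c1ccc2c(c1)OC[C@H](Cc1ccccc1)[C@H]2O` has not yet been measured. It differs from compound 2 by chloro in place of trifluoromethyl on an aromatic carbon. Among the compounds with values here, no measured pair isolates this exchange, so the size of the step is not known from the data; a change no larger than the usual scatter is expected, with a slight lean towards weaker inhibition. For compound 3 an inhibitory concentration of 400 nM is estimated, within 150 nM to 1000 nM, which means an expected step of a 1.4-fold higher number from compound 2 to compound 3 (0.15 log units; within the scatter).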

Compound 3, half-maximal inhibitory concentration: 265 nM
Estimate against measurement, compound 3: 1.5-fold (0.18 log units) above; the measured number falls inside the stated range.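

In this assay, the exchange of trifluoromethyl for chloro on the aromatic carbon para to a carboxy group now has a measured size: a 1.1-fold lower number from compound 2 to compound 3 (0.02 log units; within the scatter). At this position in this pair, the single chlorine atom and the trifluoromethyl group, with its 4 heavy atoms, cannot be told apart by this read-out. Repeat entries of one compound give a yardstick for judging so small a step: the several entries of compound 1 in this assay, 590 nM; 520 nM (2 entries)

From the compounds shown here alone, whether other groups on this carbon, such as a methyl, a methoxy group, a nitrile or an amine, would also leave the read-out in the same range remains open. Going by these compounds, it is also open whether the exchange would behave the same way alongside the larger side chain of compound 1.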